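The source may hold more compounds than are shown below. What is called first, only, known or untested is meant among the compounds shown, and "the series" means these compounds.

Values measured in a physicochemical assay for solubility, at pH 6.8; a higher number here means a more soluble compound, a lower number a less soluble compound:
- compound 1 `CN(C)Cc1ccc(-c2cnc(N)c(C(=O)NC[C@@](C)(O)C(F)(F)F)n2)cc1`: 510000 nM
- compound 2 `CN(C)Cc1ccc(-c2cnc(N)c(C(=O)NC3CCC(O)CC3)n2)cc1`: 850000 nM
- compound 3 `CC(C)NC(=O)c1nc(-c2ccc(CN(C)C)cc2)cnc1N`: > 1000000 nM (a limit of the assay, not a number)

Compound 3 has no exact value, as it sits at the limit of > 1000000 nM in this assay, at which 1 of the 3 values shown sits. Compound 4 `CC(O)CNC(=O)c1nc(-c2ccc(CN(C)C)cc2)cnc1N` carries 2-hydroxypropyl in place of isopropyl on an amide-type nitrogen. Among the compounds with values here, two measured steps bear on this change. Both arrive at the isopropyl amide, so they run in the opposite sense: an at least 1.9-fold higher number from compound 1 to compound 3 (0.29 log units; that floor lies within the scatter) and an at least 1.1-fold higher number from compound 2 to compound 3 (0.07 log units; that floor lies within the scatter). Both lie within the scatter, so no step beyond the scatter is expected in this assay. The estimated step is an at least 1.1-fold lower number from compound 3 to compound 4 (0.07 log units; that floor lies within the scatter). For compound 4 the expected value is 850000 nM, with an estimated range of 500000 nM to 1000000 nM.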

Compound 4, solubility: > 1000000 nM
Compound 4 ended at the assay's limit; the forecaster's own chance of this, stated with the estimate: 45%; at least 1.1-fold (0.07 log units) between middle value and limit.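

In this assay compound 4, with 2-hydroxypropyl on the amide-type nitrogen, gives > 1000000 nM, which is a limit of the assay and not a number. So a hydroxyl-bearing chain at this position can also reach that limit, though the comparisons with the other hydroxyl-bearing amides give only floors: an at least 1.1-fold higher number from compound 2 to compound 4 (0.07 log units; that floor lies within the scatter) and an at least 1.9-fold higher number from compound 1 to compound 4 (0.29 log units; that floor lies within the scatter). The step between the isopropyl and 2-hydroxypropyl amides cannot be read, because both compounds sit at the limit: the limit of > 1000000 nM in this assay, at which 2 of the 4 values shown sit.

From the compounds shown here alone, how far beyond the limit compound 3 and compound 4 lie remains open. Also open, going by these compounds, is whether an amine or a carboxylic acid on this chain would keep the read-out at the limit.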